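Fluoro-to-chloro exchanges in a vinyl sulfone series

A few compounds are considered here, and "the series" means these few. Any claim that something is new, unique, unknown or untested is made for them only; others in the source may bear on it.

Measured compounds:
compound 1 `O=S(=O)(/C=C/c1ncccc1F)c1ccccc1F`: 176 nM
compound 2 `O=S(=O)(/C=C/c1ncccc1Cl)c1ccccc1F`: 30 nM
compound 3 `O=S(=O)(/C=C/c1cccnc1Cl)c1ccc(F)cc1`: 339 nM

In an assay on U2OS cells for activation of nuclear factor erythroid 2-related factor 2 (Homo sapiens), read by beta-arrestin recruitment, with a stated time of 6 h (a higher number here means that more compound is needed for the effect, a lower number that less compound is needed), compound 1 gives 176 nM and compound 2 gives 30 nM. The change between them is chloro in place of fluoro on an aromatic carbon, and the step is a 5.9-fold lower number from compound 1 to compound 2 (0.77 log units; beyond the scatter). Compound 3 gives 339 nM in this assay; how its core differs from that of compound 1 is not broken down here. Compound 4 `O=S(=O)(/C=C/c1cccnc1Cl)c1ccc(Cl)cc1` is not yet measured. It differs from compound 3 by chloro in place of fluoro on an aromatic carbon, the same kind of change as from compound 1 to compound 2, but the place is not the same: there the chloro sits on a six-membered aromatic ring with 1 nitrogen, ortho to a large group, two atoms from the ring nitrogen; here it sits on a six-membered aromatic ring of carbon only, para to a large group. Among the measured compounds shown here, because the earlier step was a 5.9-fold lower number from compound 1 to compound 2 (0.77 log units; beyond the scatter), compound 4 is expected to give a lower number than compound 3, but a smaller step is estimated, since only one such step is known and it sits elsewhere: a 2.0-fold lower number from compound 3 to compound 4 (0.30 log units; within the scatter). The estimate for compound 4 in this assay is 170 nM, expected between 60 nM and 500 nM.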

Compound 4, half-maximal effective concentration: 305 nM
The estimate for compound 4 lay 1.8-fold (0.25 log units) below the measured number; low and high end bracket the measured number.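

In this assay, chloro in place of fluoro on an aromatic carbon does not carry a fixed step from one core to another: the same change on two cores in this assay, a 5.9-fold lower number (0.77 log units; beyond the scatter) from compound 1 to compound 2 and a 1.1-fold lower number (0.05 log units; within the scatter) from compound 3 to compound 4, 5.3-fold (0.72 log units) apart, beyond the scatter of two such steps

On the six-membered aromatic ring of carbon only, para to a large group, the exchange gives a 1.1-fold lower number from compound 3 to compound 4 (0.05 log units; within the scatter). Core and place of the exchange differ together across the two steps, and these data do not separate them; two steps also set no rule for further cores.

Still open, as far as these compounds go, is the size of the same exchange on the ring with nitrogen in the core of compound 3. Also open, from the compounds shown here alone, is what a methoxy group or a nitrile would give on the aromatic carbon para to a large group.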